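Series notes: cyclopropyl in place of heptyl, compound 4

This account rests on a few compounds, and the source may have more. Where it says the series, first, only, none or still open, it means among the compounds named here.

Compound 1 `CCCCCCCc1cn(C(c2ccccc2)c2cc3cc(Br)ccc3nc2OC)nn1` carries a heptyl group on the shared core. In an ADME assay on HeLa cells (Homo sapiens) for cytotoxicity, read by sulforhodamine B assay, with a stated time of 48 h, tested at 10 uM (a higher number here means more inhibition at the concentration tested (going by the name of the read-out), a lower number less inhibition), compound 1 gives 9.7%, second highest of the three numbers measured. Compound 2 `COc1nc2ccc(Br)cc2cc1C(c1ccccc1)n1cc(-c2ccccc2F)nn1` gives 14.1% in this assay, a change of a number 4.4 percentage points higher from compound 1 to compound 2 (within the scatter). Compound 3 `COc1nc2ccc(Br)cc2cc1C(c1ccccc1)n1cc(-c2ccccc2C(F)(F)F)nn1` gives -1.3%, a change of a number 11 percentage points lower from compound 1 to compound 3 (beyond the scatter); between compound 2 and compound 3 the step is a number 15.4 percentage points lower from compound 2 to compound 3 (beyond the scatter).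

Compound 4 `COc1nc2ccc(Br)cc2cc1C(c1ccccc1)n1cc(C2CC2)nn1` differs from compound 1 by cyclopropyl in place of heptyl on an aromatic carbon. The measured steps that bear on it are those that also replace the heptyl group, from compound 1 to compound 2 and from compound 1 to compound 3: one within the scatter, one a modest fall. For the measured compounds named here, no measured compound carries cyclopropyl, so the expectation rests on those two steps alone. In this assay a step of at most modest size, more likely flat or slightly lower, is therefore expected for compound 4, that is a number 3.7 percentage points lower from compound 1 to compound 4 (within the scatter). Compound 4 is estimated at 6% in this assay, within -6% to 18%.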

Compound 4, a percentage reported as inhibition, at one concentration (the size of the read-out at that concentration, not a potency): -5.84%
Compound 4: middle estimate off by 11.8 percentage points, on the high side; the measured number falls inside the stated range.
By their numbers in this assay, from the lowest: compounds 4 and 3 (each within the scatter of the next); then compounds 1 and 2 (each within the scatter of the next).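

Cyclopropyl in place of heptyl on this aromatic carbon also lowers the number in this assay, a number 15.5 percentage points lower from compound 1 to compound 4 (beyond the scatter), so a fall on losing heptyl does not depend on an aryl replacement; the 2-fluorophenyl group goes against any general fall, as its step from heptyl stays within the scatter. Cyclopropyl and 2-fluorophenyl are clearly separated, a number 19.9 percentage points lower from compound 2 to compound 4 (beyond the scatter), whereas cyclopropyl and 2-(trifluoromethyl)phenyl cannot be told apart, a number 4.5 percentage points lower from compound 3 to compound 4 (within the scatter). Nothing available explains these differences.

Open, from the compounds shown here alone, is whether the number changes gradually with chain length, as a propyl or pentyl chain at this carbon would show. Also open, going by these compounds, is how an amine or a carboxylic acid at the end of such a chain would read here.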